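The compounds below may be only part of what the source reports. "The series", "measured", "known", "first", "only" and "open" are said of these compounds alone.

Measured compounds:
- compound 1 `C#CCOC[C@H](COC(=O)CCCCCCC/C=C\CCCCCCCC)OP(=O)(O)OC[C@H](N)C(=O)O` gives 3.2%
- compound 2 `CCCCCCCC/C=C\CCCCCCCC(=O)OC[C@@H](COCCC)OP(=O)(O)OC[C@H](N)C(=O)O` is reported as "not active" (no number reported)

In an assay on HEK293 cells for agonist activity at putative P2Y purinoceptor 10 (Mus musculus), with a stated time of 1 h (on this read-out higher numbers stand for larger maximal responses and lower numbers for smaller maximal responses), compound 1 gives 3.2%, a small maximal response. In this assay compound 2 is recorded as "not active" (no number reported), so no number stands for it, and it can only be placed as showing no measurable response. Compound 3 `CCCCCCCC/C=C\CCCCCCCC(=O)OC[C@@H](COCc1ccccc1)OP(=O)(O)OC[C@H](N)C(=O)O` has not been measured yet. It differs from compound 2 by phenyl in place of ethyl on a saturated chain carbon bound to an oxygen on a saturated carbon. Going by the values given here, with no measured pair showing such a change, the size of the step in this assay cannot be read from the data; a response within the scatter of compound 2, or a small rise, is expected. Compound 3 is estimated to give 5%, within a range from 0% to 20%.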

Compound 3, largest response reached (Emax), in percent of the reference or control that the assay uses: 7.3%
For compound 3 the middle estimate is 2.3 percentage points below the measured one, and the stated range covers the measured number.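

In this assay, the change gives a number 4.1 percentage points higher from compound 1 to compound 3 (within the scatter), so at this place, on a saturated chain carbon bound to an oxygen on a saturated carbon, phenyl and ethynyl cannot be told apart. Compound 3, with its phenyl, has a number, whereas compound 2, with ethyl there, is recorded as not active, so the size of that step cannot be read. Nothing measured here offers an explanation for these results. On these data alone, whether an amine, a carboxylic acid or a longer chain at this place would give a clearly larger response remains open.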